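The source may hold more compounds than are shown below. What is called first, only, known or untested is meant among the compounds shown, and "the series" means these compounds.

In a functional assay on MCF7 cells (Homo sapiens) for cytotoxicity, read by CellTiter-Glo, with a stated time of 5 days (on this read-out lower numbers stand for stronger inhibition and higher numbers for weaker inhibition), compound 1 `CC/C(=C(/c1ccc(/C=C/C(=O)O)cc1)c1ccc2cn[nH]c2c1)c1ccccc1` gives 570 nM and compound 2 `CC/C(=C(/c1ccc(/C=C/C(=O)O)cc1)c1ccc2[nH]ncc2c1)c1ccccc1Cl` gives 2 nM as the lower of the two numbers, a gap well beyond the usual scatter. Compound 3 `CC/C(=C(/c1ccc(/C=C/C(=O)O)cc1)c1ccc2[nH]ncc2c1)c1cccc(C#N)c1` has not yet been measured. It carries 3-cyanophenyl in place of 2-chlorophenyl on a double-bonded chain carbon bound to a double-bonded chain carbon and a saturated chain carbon. Within the data shown here, no measured step covers this exact change. A moderately weaker number is expected in this assay as the estimated step (a 10-fold higher number from compound 2 to compound 3 (1.00 log units; beyond the scatter)) beyond the scatter. Compound 3 is expected to read 20 nM within an estimated range from 3 nM to 150 nM in this measurement.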

Compound 3, half-maximal inhibitory concentration: 100 nM
Beside the measured number, compound 3's estimate is 5.0-fold (0.70 log units) below it; measured number inside the range.
By their numbers in this assay, from the lowest: compound 2; then compound 3; then compound 1.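

In this assay, placing 3-cyanophenyl in place of 2-chlorophenyl on this double-bonded chain carbon gives a 50-fold higher number from compound 2 to compound 3 (1.70 log units; beyond the scatter) and shows that the number depends strongly on which substituted phenyl sits there. The change replaces the substituent and also moves it on the ring, so the step cannot be assigned to either alone. No measurement here explains the loss. Open, from the compounds shown here alone, is whether a chlorine or a nitrile would read differently at one same ring position, and how a methoxy group or an amine on this ring would read.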